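The source may hold more compounds than are shown below. What is called first, only, known or untested is meant among the compounds shown, and "the series" means these compounds.

Series notes, measured so far in a functional assay on HeLa cells (Homo sapiens) for antiproliferative activity, read by MTT assay, with a stated time of 72 h; a lower number here means a stronger inhibitor, a higher number a weaker inhibitor; each value is a limit of the assay, not a number:

compound 1 `COCn1c(CC(O)(CO)CO)cc(=O)[nH]c1=O`: > 100000 nM
compound 2 `C[Si](C)(C)CCOCn1c(CC(O)(CO)CO)cc(=O)[nH]c1=O`: > 100000 nM
compound 3 `Cc1c(CC(O)COCc2ccccc2)n(COCC[Si](C)(C)C)c(=O)[nH]c1=O`: > 100000 nM

All three sit at the limit of > 100000 nM in this assay, at which 3 of the 3 values shown sit. From compound 2 to compound 1 the change is a hydrogen atom in place of a group of 5 heavy atoms (4 carbon, 1 silicon; no ring), on a saturated chain carbon bound to an oxygen on a saturated carbon; the step that the two limits leave unreadable from compound 2 to compound 1 cannot be sized because both ends are limits. Compound 4 `COCn1c(CC(O)COCc2ccccc2)c(C)c(=O)[nH]c1=O` is not yet measured. It differs from compound 3 by a hydrogen atom in place of a group of 5 heavy atoms (4 carbon, 1 silicon; no ring), on a saturated chain carbon bound to an oxygen on a saturated carbon, the same change as from compound 2 to compound 1, at the same place. The difference between the cores of compound 2 and compound 3 is not broken down here.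

With every measured compound at the limit, the step from compound 3 to compound 4 is expected to be a step that the limit leaves unreadable from compound 3 to compound 4, resting on the unreadable step that the two limits leave unreadable from compound 2 to compound 1. Compound 4 is accordingly estimated at 150000 nM, between 40000 nM and 600000 nM, most likely reported only as a limit.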

Compound 4, half-maximal inhibitory concentration: > 100000 nM
Compound 4: a limit, no number; the forecaster's own chance of this, stated with the estimate: 85%; the middle value is on the limit's open side.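

Compound 3 and compound 4 both stand as limits, not numbers, so no step can be read between them. The compounds shown leave open whether any member of this series has a measurable potency in this assay: the limit of > 100000 nM in this assay, at which 4 of the 4 values shown sit.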